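From a limit toward compound 3

This account rests on a few compounds, and the source may have more. Where it says the series, first, only, none or still open, it means among the compounds named here.

Compound 1 `O=C(NC[C@@H]1[C@H]2CN(C(=O)C3CC3c3cc(Cl)cc(Cl)c3)C[C@@H]12)c1ccc2[nH]c(=O)oc2c1`: < 1 ug/mL, a limit
Compound 2 `O=C(NC[C@@H]1[C@H]2CN(C(=O)NCc3cc(Cl)cc(Cl)c3)C[C@@H]12)c1ccc2[nH]c(=O)oc2c1`: < 1 ug/mL, a limit

In a physicochemical assay for solubility, with a stated time of 24 h, at pH 4.5 (a higher number here means a more soluble compound, a lower number a less soluble compound), compound 2 gives < 1 ug/mL, which is a limit and not a number. Among the compounds with values here, the measured series so far stands at one place: the limit of < 1 ug/mL in this assay, at which 2 of the 2 values shown sit. Compound 3 `Cc1ccc(COC(=O)N2C[C@@H]3[C@@H](CNC(=O)c4ccc5[nH]c(=O)oc5c4)[C@@H]3C2)nc1` keeps the shared core and differs from compound 2 in one group: a group of 9 heavy atoms (7 carbon, 1 nitrogen, 1 oxygen; one six-membered aromatic ring with 1 hetero atom) in place of a group of 10 heavy atoms (7 carbon, 1 nitrogen, 2 chlorine; one six-membered aromatic ring of carbon only), on a carbonyl carbon. The (3,5-dichlorobenzyl)amino group leaves the carbonyl carbon, and the incoming group has no common name. Within the data shown here, the one measured step that bears on this is a step that the two limits leave unreadable from compound 1 to compound 2, so it offers no size to carry over. For compound 3 an upward step is expected, an at least 4.0-fold higher number from compound 2 to compound 3 (0.60 log units; beyond the scatter), an estimate resting on the structural change alone. A result at the same limit would remain possible. Compound 3 is estimated at 4 ug/mL, with an expected range from 1 ug/mL to 30 ug/mL.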

Compound 3, solubility: 66 ug/mL
Estimate against measurement, compound 3: 17-fold (1.22 log units) below; measured number outside the range, above it.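

In this assay, the group on the carbonyl carbon, whose other neighbour is an amide-type nitrogen in a ring, now proves able to move the read-out off the limit. Exchanging the (3,5-dichlorobenzyl)amino group for the incoming group with its six-membered aromatic ring with 1 hetero atom gives an at least 66-fold higher number from compound 2 to compound 3 (1.81 log units; beyond the scatter), and replacing the group of compound 1 gives an at least 66-fold higher number from compound 1 to compound 3 (1.81 log units; beyond the scatter). The step between compound 1 and compound 2 cannot be read, as both stay at a limit and not a number: the limit of < 1 ug/mL in this assay, at which 2 of the 3 values shown sit.

Compound 3 changes the ring, the chlorines and the link to the carbonyl carbon in one group, and the compounds shown do not separate these parts. Going by these compounds, whether a plain benzyl group or a morpholine in that place would give a similar value remains open.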